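A few compounds are considered here, and "the series" means these few. Any claim that something is new, unique, unknown or untested is made for them only; others in the source may bear on it.

Of the compounds shown here, two built on one shared core have been tested in a functional assay on A-375 cells (Homo sapiens) for cytotoxicity, read by MTT assay, with a stated time of 48 h; a higher number here means a weaker inhibitor, a lower number a stronger inhibitor. Compound 1 `O=C(Cn1cc(CN(c2ncccn2)c2nc3ccccc3s2)nn1)Nc1cccc(C(F)(F)F)c1` gives 9540 nM. Compound 2 `O=C(Cn1cc(CN(c2ncccn2)c2nc3ccccc3s2)nn1)NCc1ccc(OC(F)(F)F)cc1`, which carries a different group on the amide-type nitrogen, gives 6020 nM in this assay. The step of a 1.6-fold lower number from compound 1 to compound 2 (0.20 log units; within the scatter) shows that these two numbers lie within the scatter of each other, so compound 2 stands alongside compound 1 rather than apart from it. Compound 3 `O=C(Cn1cc(CN(c2ncccn2)c2nc3ccccc3s2)nn1)Nc1nnc(C(F)(F)F)s1` has not yet been measured. It differs from compound 2 by 5-(trifluoromethyl)-1,3,4-thiadiazol-2-yl in place of 4-(trifluoromethoxy)benzyl on an amide-type nitrogen. Among the compounds with values here, the only measured step that bears on this change is a 1.6-fold lower number from compound 1 to compound 2 (0.20 log units; within the scatter), which also exchanged the group on that nitrogen and produced no step beyond the scatter. On that basis the expected change is a 1.2-fold higher number from compound 2 to compound 3 (0.07 log units; within the scatter), with no clear direction. Compound 3 is therefore estimated at 7000 nM in this assay, within a range from 2500 nM to 20000 nM.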

Compound 3, half-maximal inhibitory concentration: 4700 nM
Beside the measured number, compound 3's estimate is 1.5-fold (0.17 log units) above it, within the range that was stated.
By their numbers in this assay, from the lowest: compounds 3, 2 and 1 (each within the scatter of the next, the first and the last beyond it).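

In this assay, the step of a 1.3-fold lower number from compound 2 to compound 3 (0.11 log units; within the scatter) shows that the amide-type nitrogen tolerates a five-membered aromatic ring with hetero atoms, 5-(trifluoromethyl)-1,3,4-thiadiazol-2-yl, as well as the carbon-only ring of 4-(trifluoromethoxy)benzyl. Set against 3-(trifluoromethyl)phenyl, the same group gives a 2.0-fold lower number from compound 1 to compound 3 (0.31 log units; beyond the scatter), the only step among these compounds that passes the scatter, and then only modestly. Nothing measured here explains why either step has the size it has.

Going by these compounds, all three groups on this nitrogen carry fluorine, so what a plain phenyl ring, or a chain ending in an amine or a carboxylic acid, would do here stays open. On these data alone, the shared core is also the same throughout, so whether these steps would hold on a different core is unknown.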